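The source may hold more compounds than are shown below. What is called first, only, known or untested is meant among the compounds shown, and "the series" means these compounds.

Among the measured compounds shown here, compound 2 `OCCCNc1nc(-c2ccccc2)nc2c1nnn2Cc1ccccc1` is the reference point of this step; in an assay on isolated protein for binding affinity to adenosine receptor A1 (Bos taurus) (a lower number here means a stronger inhibitor, a higher number a weaker inhibitor), compound 2 gives 21400000 nM, the highest of the three numbers measured so far. Compound 1 `CCCCCCNc1nc(-c2ccccc2)nc2c1nnn2Cc1ccccc1` gives 13200000 nM in this assay, and compound 3 `OCCCNc1nc(-c2ccccc2)nc2c1nnn2Cc1ccccc1F` gives 3700000 nM. Compound 4 `c1ccc(Cn2nnc3c(NC4CC4)nc(-c4ccccc4)nc32)cc1` is still to be measured. The change is cyclopropyl in place of 3-hydroxypropyl on a nitrogen on an aromatic ring. Of the measured steps only a 1.6-fold higher number from compound 1 to compound 2 (0.21 log units; within the scatter) alters the same chain on the ring nitrogen, and it lay within the scatter; the other step, a 5.8-fold lower number from compound 2 to compound 3 (0.76 log units; beyond the scatter), is fluoro in place of hydrogen on an aromatic carbon and does not bear here. Exchanging one chain for another on that nitrogen has therefore shown nothing beyond the scatter, so for compound 4 only a small step toward a lower number, if any, is expected, a 1.8-fold lower number from compound 2 to compound 4 (0.25 log units; within the scatter). The estimate for compound 4 is 12000000 nM with a range from 3000000 nM to 50000000 nM.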

Compound 4, inhibition constant: 11000000 nM
Compound 4: middle estimate off by 1.1-fold (0.04 log units), on the high side, and the stated range covers the measured number.
By their numbers in this assay, from the lowest: compound 3; then compounds 4, 1 and 2 (each within the scatter of the next).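

In this assay, a ring on the nitrogen reads no differently from an open chain: a 1.9-fold lower number from compound 2 to compound 4 (0.29 log units; within the scatter) and a 1.2-fold lower number from compound 1 to compound 4 (0.08 log units; within the scatter) both lie within the scatter, so cyclopropyl, 3-hydroxypropyl and hexyl cannot be ordered at this position. Cyclopropyl has no hydrogen-bond donor or acceptor where 3-hydroxypropyl has one of each, and this difference also leaves the number within the scatter. No data at hand explain this flat reading. As far as these compounds go, whether an amine, a carboxylic acid or a benzyl group on that nitrogen would move the number beyond the scatter remains open.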